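The compounds below may be only part of what the source reports. "The series", "measured", "known", "first", "only" and "open" are said of these compounds alone.

Within the data shown here, compound 1, `CCCCC(Sc1nc(Cl)cc(Nc2ccc3ncccc3c2)n1)C(=O)OCC`, is the only member of the pair with a number to its name in an assay for inhibition of Polyunsaturated fatty acid 5-lipoxygenase (Homo sapiens), tested at 1 uM (on this read-out higher numbers stand for a weaker effect at the one concentration tested and lower numbers for a stronger effect), where compound 1 gives 51.8%. Among the measured compounds shown here, compound 2, `CCOC(=O)CSc1nc(Cl)cc(Oc2ccc3ncccc3c2)n1`, is recorded only as "not active" (no number reported) in this assay, without a number, so it offers no measured step against compound 1, and it differs from compound 1 in more than one place, so no single difference is counted for it.

Compound 3, `CCOC(=O)C(C)Sc1nc(Cl)cc(Nc2ccc3ncccc3c2)n1`, has not yet been measured in this assay. It differs from compound 1 by hydrogen in place of propyl on a saturated chain carbon, two bonds along the chain from a carbonyl carbon and a sulfur. Cut one bond further out, the same difference reads butyl to methyl.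

For the measured compounds named here, no step between measured compounds is available to anchor this change. Compound 2, which also carries a short chain at that carbon but differs elsewhere too, gives no usable direction. The loss of the propyl is expected to shift the read-out toward a weaker effect, by a modest amount that may not exceed the scatter. Compound 3 is expected to give 65%, with a range from 42% to 92%, which means a step of a number 13.2 percentage points higher from compound 1 to compound 3 (beyond the scatter).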

Compound 3, a percentage reported as activity, at one concentration (the size of the read-out at that concentration, not a potency): "not active" (no number reported)
For compound 3 the study gives words and no number; no gap can be computed for the estimate.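

In this assay, among these compounds, compound 3 is recorded only in words as "not active" (no number reported) and so gives no step that can be read against compound 1. No measured evidence bears on this result. The compounds shown leave open how far the read-out moves when propyl gives way to hydrogen on that saturated chain carbon.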